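Working notes: compounds 1 to 4, one still unmeasured

The source may report more compounds than this note shows. Statements on the series, on what has been measured and on what is new or still open speak of the compounds shown alone.

Measured so far, in a functional assay on PC-3 cells (Homo sapiens) for cytotoxicity, read by MTT assay, with a stated time of 72 h; on this read-out higher numbers stand for weaker inhibition and lower numbers for stronger inhibition:
compound 1 `COc1ccc(S(=O)(=O)c2nc3ccccc3nc2N2CCc3ccccc3C2)cc1`: > 50000 nM
compound 2 `O=S(=O)(c1ccc(Br)cc1)c1nc2ccccc2nc1N1CCc2ccccc2C1`: > 50000 nM
compound 3 `COc1ccc(S(=O)(=O)c2nc3ccccc3nc2N2CCCC(O)C2)cc1`: 3410 nM

Compound 1 gives > 50000 nM in this assay, which is a limit of the assay and not a number. Compound 2 likewise gives > 50000 nM in this assay, again a limit. Compound 3 is the only one of the three with a number, 3410 nM in this assay.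

The difference between compound 1 and compound 2 is bromo in place of methoxy on an aromatic carbon. The step that the two limits leave unreadable from compound 1 to compound 2 cannot be read because both compounds sit at the limit of > 50000 nM in this assay, at which 2 of the 3 values shown sit. The cores of compound 1 and compound 3 differ by 3-hydroxypiperidin-1-yl in place of 1,2,3,4-tetrahydroisoquinolin-2-yl on an aromatic carbon, and that change gives an at least 14-fold lower number from compound 1 to compound 3 (1.16 log units; beyond the scatter).

Compound 4 `O=S(=O)(c1ccc(Br)cc1)c1nc2ccccc2nc1N1CCCC(O)C1` has not yet been measured. Among the compounds with values here, it differs from compound 3 by bromo in place of methoxy on an aromatic carbon, the same change as the one from compound 1 to compound 2, with the place described in the same words. Within the data shown here, the earlier instance of this change is unreadable, so no measured step guides the expectation; the only anchor is compound 3 at 3410 nM. Compound 4 is therefore expected to sit close to compound 3, with the step of a 1.3-fold higher number from compound 3 to compound 4 (0.12 log units; within the scatter), and with wide uncertainty in both directions. The estimate for compound 4 in this assay is 4500 nM, expected between 1500 nM and 15000 nM.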

Compound 4, half-maximal inhibitory concentration: 3690 nM
Compound 4: middle estimate off by 1.2-fold (0.09 log units), on the high side, within the range that was stated.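

In this assay, bromo in place of methoxy gives a 1.1-fold higher number from compound 3 to compound 4 (0.03 log units; within the scatter), so on this core the two groups cannot be told apart, while the same change on the core of compound 1 cannot be read; this single readable pair does not show how that change behaves across cores. The other change, 3-hydroxypiperidin-1-yl in place of 1,2,3,4-tetrahydroisoquinolin-2-yl, gives an at least 13-fold lower number from compound 2 to compound 4 (1.13 log units; beyond the scatter), and it now appears with both the 4-methoxyphenyl and the 4-bromophenyl group: the same change on two cores in this assay, an at least 14-fold lower number (1.16 log units; beyond the scatter) from compound 1 to compound 3 and an at least 13-fold lower number (1.13 log units; beyond the scatter) from compound 2 to compound 4; the limit leaves it open whether they differ. From the compounds shown here alone, this change therefore goes to a lower number in both pairs, but its true size stays unknown and neither pair gives an exact step, as compound 1 and compound 2 rest on limits and not on numbers: the limit of > 50000 nM in this assay, at which 2 of the 4 values shown sit.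

The compounds shown leave open whether the hydroxyl of the 3-hydroxypiperidin-1-yl group is needed, and how a plain piperidin-1-yl or a 3-aminopiperidin-1-yl group would read in this assay. They also leave open how the 3-hydroxypiperidin-1-yl series would read with a nitrile or a carboxylic acid in place of bromo.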